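The source may hold more compounds than are shown below. What is called first, only, known or untested is meant among the compounds shown, and "the series" means these compounds.

Compound 1 `N#CC1=C(N)Oc2c(c3nc4ccccc4nc3c3ccccc23)C12C(=O)N(Cc1cnnn1-c1cccc(S(N)(=O)=O)c1)c1ccccc12` gives 38600 nM in an ADME assay on HUVEC cells (Homo sapiens) for antiproliferative activity, read by MTT assay, with a stated time of 48 h; a lower number here means a stronger inhibitor, a higher number a weaker inhibitor. Compound 2 `Cc1ccc(-n2nncc2CN2C(=O)C3(C(C#N)=C(N)Oc4c3c3nc5ccccc5nc3c3ccccc43)c3ccccc32)cc1Cl` returns only the assay limit, > 50000 nM, in this assay. For the measured compounds named here, the one measured step, an at least 1.2-fold higher number from compound 1 to compound 2 (0.11 log units; that floor lies within the scatter), ends at the limit of > 50000 nM in this assay, at which 1 of the 2 values shown sits. Compound 3 `Cc1ccc(Cl)cc1-n1nncc1CN1C(=O)C2(C(C#N)=C(N)Oc3c2c2nc4ccccc4nc2c2ccccc32)c2ccccc21` differs from compound 2 by 5-chloro-2-methylphenyl in place of 3-chloro-4-methylphenyl on an aromatic nitrogen; the two hold the same atoms in a different arrangement. Compound 2 stands at the limit and an at least 1.2-fold higher number from compound 1 to compound 2 (0.11 log units; that floor lies within the scatter) stays within the scatter, so no step beyond the scatter is expected. The expected step that the limit leaves unreadable from compound 2 to compound 3 is therefore flat. Compound 3 is estimated at 60000 nM, between 25000 nM and 150000 nM, most likely reported as a limit again.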

Compound 3, half-maximal inhibitory concentration: > 50000 nM
Compound 3 gave a limit, no number; the forecaster's own chance of this, stated with the estimate: 70%; the middle value lies beyond the limit too.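

In this assay, neither chlorine-and-methyl arrangement on the phenyl group gives a readable number, and the step between compound 2 and compound 3 cannot be read, as both values are limits. Replacing 3-sulfamoylphenyl with 5-chloro-2-methylphenyl gives an at least 1.2-fold higher number from compound 1 to compound 3 (0.11 log units; that floor lies within the scatter), so this second arrangement also shows no change beyond the scatter. The series now stands as follows: the limit of > 50000 nM in this assay, at which 2 of the 3 values shown sit.

On these data alone, it remains open whether any group on this aromatic nitrogen can give a number well under that limit. A phenyl group carrying an amine or a carboxylic acid would extend the comparison with compound 1.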